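The source may hold more compounds than are shown below. What is called first, only, known or untested is meant among the compounds shown, and "the series" means these compounds.

Compound 1 `O=C1c2ccccc2C(=O)N1CCOC(=S)N(C(=O)c1ccc([N+](=O)[O-])cc1)c1ccc(Cl)cc1` is examined in an ADME assay on MT4 cells (Homo sapiens) for cytotoxicity, read by MTT assay; a lower number here means that less compound is tolerated, a higher number that more compound is tolerated. In this assay compound 1 gives > 100000 nM, which is a limit of the assay rather than a number. Compound 2 `O=C1c2ccccc2C(=O)N1CCOC(=S)N(C(=O)c1cccnc1Cl)c1ccc(Br)cc1` likewise gives > 100000 nM in this assay, again a limit. Compound 3 `Cc1ccc(N(C(=O)c2ccc([N+](=O)[O-])cc2)C(=S)OCCN2C(=O)c3ccccc3C2=O)cc1`, which carries a methyl in place of chloro on an aromatic carbon, gives 58000 nM in this assay, a real number. That step, an at least 1.7-fold lower number from compound 1 to compound 3 (0.23 log units; that floor lies within the scatter), is the only measured one here, and it stays within the scatter. Compound 1 therefore stands at the limit of > 100000 nM in this assay, at which 2 of the 3 values shown sit.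

Compound 4 `O=C1c2ccccc2C(=O)N1CCOC(=S)N(C(=O)c1c(Cl)cccc1Cl)c1ccc(Cl)cc1` differs from compound 1 in one place: 2,6-dichlorophenyl in place of 4-nitrophenyl on a carbonyl carbon. Within the data shown here, no measured step exchanges the group on the carbonyl carbon, and the one step that is measured, at another place, produced nothing beyond the scatter. On this basis compound 4 is expected to stay near compound 1 in this assay, with the estimate 100000 nM, spanning 30000 nM to 300000 nM, which means an expected step of a number no higher from compound 1 to compound 4 (the limit leaves the size open).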

Compound 4, half-maximal cytotoxic concentration: 20000 nM
The estimate for compound 4 lay 5.0-fold (0.70 log units) above the measured number; the whole stated range lies above it.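

In this assay, putting 2,6-dichlorophenyl in place of 4-nitrophenyl on the carbonyl carbon gives an at least 5.0-fold lower number from compound 1 to compound 4 (0.69 log units; beyond the scatter), which makes this the only change shown that clears the scatter. The other step, made at another place, is an at least 1.7-fold lower number from compound 1 to compound 3 (0.23 log units; that floor lies within the scatter), so the group on the carbonyl carbon is where a real difference in tolerated concentration first appears. Compound 1 itself sits at a limit of the assay, so this step has only a floor and its full size stays unknown: the limit of > 100000 nM in this assay, at which 2 of the 4 values shown sit.

A single pair cannot separate the loss of 4-nitrophenyl from the gain of 2,6-dichlorophenyl as the source of the lower number. From the compounds shown here alone, it also remains open how an unsubstituted phenyl, or a phenyl carrying an amine or a carboxylic acid, would read on that carbonyl carbon.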